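A few compounds are considered here, and "the series" means these few. Any claim that something is new, unique, unknown or untested is made for them only; others in the source may bear on it.

Compound 1 `CCN(CC)CCCC(C)Nc1ncnc2c1C(=O)C(OC)=CC2=O`: 0.435 ug/mL
Compound 2 `CCN(CC)CCNc1ncnc2c1C(=O)C(OC)=CC2=O`: 0.281 ug/mL

Both compounds were tested in a functional assay on L1210 cells (Mus musculus) for inhibition; a lower number here means a stronger inhibitor, a higher number a weaker inhibitor. Compound 2, at 0.281 ug/mL, stands within the usual scatter of compound 1, at 0.435 ug/mL, so these numbers do not separate the pair. The next compound to be tested in this assay is compound 3 `COC1=CC(=O)c2ncnc(NCCN(C)C)c2C1=O`. It departs from compound 2 by a single change: dimethylamino in place of diethylamino on a saturated chain carbon, two bonds along the chain from a nitrogen on an aromatic ring. In words, dimethylamino stands in place of diethylamino on a saturated chain carbon, two bonds along the chain from a nitrogen on an aromatic ring.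

Within the data shown here, the measured compounds include no pair that differ in one place, so the data give no direct size for this change. The shared core is retained, and the expectation is therefore for no step beyond the scatter in either direction. The estimated change is a 1.1-fold higher number from compound 2 to compound 3 (0.03 log units; within the scatter), which is expected to stay within the scatter. For compound 3 the expected value is 0.3 ug/mL, with an estimated range from 0.12 ug/mL to 0.75 ug/mL.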

Compound 3, half-maximal inhibitory concentration: 0.316 ug/mL
Compound 3: the middle estimate sits 1.1-fold (0.02 log units) below what was measured; the range from low to high includes it.
By their numbers in this assay, from the lowest: compounds 2, 3 and 1 (each within the scatter of the next).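

In this assay the step of a 1.1-fold higher number from compound 2 to compound 3 (0.05 log units; within the scatter) gives the first direct size for dimethylamino in place of diethylamino on a saturated chain carbon, two bonds along the chain from a nitrogen on an aromatic ring. At this place, a group of 3 heavy atoms and a group of 5 heavy atoms, each with no ring and the same count of hydrogen-bond donors and acceptors, are not separated by the numbers, so this pair shows no sensitivity to the change that can be read beyond the scatter. Nothing on hand offers an explanation for this result.

The compounds shown leave open whether a group that differs more from these two, such as a morpholine, a pyrrolidine or an unsubstituted primary amine, would also stay within the scatter at this place. They also leave open whether dimethylamino would behave the same way on the longer, branched chain of compound 1, which so far carries only diethylamino.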